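The source may hold more compounds than are shown below. What is called first, only, known or untested is meant among the compounds shown, and "the series" means these compounds.

Measured compounds in a functional assay on HEL cells (Homo sapiens); a higher number here means that more compound is tolerated, a lower number that less compound is tolerated:
Compound 1 `CCCCCCCCC#Cc1cc2cn(COCCO)c(=O)nc2o1` gives 42000 nM.
Compound 2 `CCCCCC#Cc1cc2cn(COCCO)c(=O)nc2o1` gives a limit, > 50000 nM.
Compound 3 `CCCCCCCCCCc1cc2cn(COCCO)c(=O)nc2o1` gives a limit, > 200000 nM.

Compound 3 stands at the limit of > 200000 nM in this assay, at which 1 of the 3 values shown sits; it has no number, only that limit. Compound 4 `CCCCc1cc2cn(COCCO)c(=O)nc2o1` differs from compound 3 by hydrogen in place of hexyl on a saturated chain carbon, four bonds along the chain from an aromatic carbon. Among the measured compounds shown here, the one measured step of the same kind, a shortening of the chain, is an at least 1.1-fold higher number from compound 1 to compound 2 (0.07 log units; that floor lies within the scatter), and compound 2 in that step also sits at a limit, (the limit of > 50000 nM in this assay, at which 1 of the 3 values shown sits). For the measured compounds named here, no step on a chain without a triple bond has been measured. The expected step for compound 4 is therefore a number no higher from compound 3 to compound 4 (the limit leaves the size open), with a limit again the likely outcome. Compound 4 is estimated at 200000 nM, range 100000 nM to 400000 nM.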

Compound 4, half-maximal cytotoxic concentration: > 200000 nM
Compound 4 gave a limit, no number; the forecaster's own chance of this, stated with the estimate: 80%; the middle value sits exactly at the limit.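

The comparisons of compound 4 with compound 3 and with compound 2 give no readable new step in this assay, as all three values are limits. As far as these compounds go, whether shortening the saturated chain changes the tolerated concentration stays open.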